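Swapping the Pyrazole Nitrogen Substituent in a Kinase Inhibitor

The source may report more compounds than this note shows. Statements on the series, on what has been measured and on what is new or still open speak of the compounds shown alone.

Measured compounds:
compound 1 `Cc1c(Nc2nc(N)c3c(C#N)c(N4CCC[C@H]4C)n(C)c3n2)cnn1CC1(O)COC1` gives 10 nM
compound 2 `C[C@H]1CCCN1c1c(C#N)c2c(N)ncnc2n1C` gives 3080 nM

Both numbers come from an assay on isolated protein for inhibition of Leucine-rich repeat serine/threonine-protein kinase 2 variant G2019S (Homo sapiens), read by TR-FRET and LanthaScreen, with stated times of 50 min and 30 min, in the presence of a further agent that is not named here; on this read-out lower numbers stand for stronger inhibition and higher numbers for weaker inhibition. Compound 1 has the lowest of the two numbers; its only companion, compound 2, lacks the whole substituted aminopyrazole arm and sits far higher, a gap well beyond the scatter.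

Compound 3 `Cc1c(Nc2nc(N)c3c(C#N)c(N4CCC[C@H]4C)n(C)c3n2)cnn1[C@@H]1CCOC1` keeps the core of compound 1 and changes only the group on the pyrazole nitrogen: oxolan-3-yl in place of (3-hydroxyoxetan-3-yl)methyl on an aromatic nitrogen. Within the data shown here, no measured pair shows such a swap on this nitrogen, so the direction of the step is not backed by data. In this assay the step from compound 1 to compound 3 is expected to stay within the scatter, giving a 1.3-fold higher number from compound 1 to compound 3 (0.11 log units; within the scatter). For compound 3 the estimated value is 13 nM, with a likely range from 4 nM to 45 nM.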

Compound 3, half-maximal inhibitory concentration: 12 nM
For compound 3 the middle estimate is 1.1-fold (0.03 log units) above the measured one, and the stated range covers the measured number.
By their numbers in this assay, from the lowest: compounds 1 and 3 (each within the scatter of the next); then compound 2.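

In this assay, putting oxolan-3-yl in place of (3-hydroxyoxetan-3-yl)methyl on the aromatic nitrogen gives a 1.2-fold higher number from compound 1 to compound 3 (0.08 log units; within the scatter) and so stays within the usual scatter. This position therefore accepts a swap between these two groups without a clear change in the number, even though the four-membered ring gives way to a five-membered ring and the entering group has 0 hydrogen-bond donors where the leaving group has 1. No measured information on either group explains why the two numbers stay so close.

The compounds shown leave open whether an amine such as piperidin-4-yl or a carboxylic acid on this nitrogen would also keep the number in this range. They also leave open how the mirror-image form of the oxolan-3-yl group would behave.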